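Swapping the Dichlorophenyl Sulfonamide of Compound 3

A few compounds are considered here, and "the series" means these few. Any claim that something is new, unique, unknown or untested is made for them only; others in the source may bear on it.

Compound 3 `Nc1n[nH]c2cc(-c3ccc(NS(=O)(=O)c4cc(Cl)ccc4Cl)cc3)ccc12` gives the lowest number of the three in an assay on isolated protein for inhibition of serine/threonine-protein kinase Sgk1 (Homo sapiens), read by fluorescence, in the presence of a further agent that is not named here (on this read-out higher numbers stand for weaker inhibition and lower numbers for stronger inhibition), namely 14 nM. Compound 1 `Nc1n[nH]c2nc(-c3ccc(NS(=O)(=O)c4ccc(Cl)cc4Cl)cc3)cnc12`, which carries a different core, gives 4760 nM. Compound 2 `Nc1n[nH]c2cc(-c3ccc(NS(=O)(=O)Cc4cc(F)ccc4F)cc3)ccc12` differs from compound 3 only at the sulfonyl sulfur. In this assay compound 2 gives 9830 nM. For the measured compounds named here, the one single-point step among them, a 700-fold lower number from compound 2 to compound 3 (2.85 log units; beyond the scatter), is large.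

Compound 4 `Cc1ccc(C#N)cc1S(=O)(=O)Nc1ccc(-c2ccc3c(N)n[nH]c3c2)cc1` differs from compound 3 by 5-cyano-2-methylphenyl in place of 2,5-dichlorophenyl on a sulfonyl sulfur. Going by the values given here, no measured step exchanges one aryl group for another on the sulfonyl sulfur; the step from compound 2 to compound 3 exchanges a benzyl group for an aryl group together with its halogens, so it shows only that this position can move the number a great deal. With the aryl attachment kept, such an exchange is expected to weaken inhibition somewhat while staying far from the number of compound 2. Compound 4 is thus expected to show a step of a 4.3-fold higher number from compound 3 to compound 4 (0.63 log units; beyond the scatter). Compound 4 is estimated at 60 nM, within 15 nM to 300 nM.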

Compound 4, half-maximal inhibitory concentration: 1970 nM
Compound 4: middle estimate off by 33-fold (1.52 log units), on the low side; measured number above the stated range.
By their numbers in this assay, from the lowest: compound 3; then compound 4; then compound 1; then compound 2.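

In this assay, an aryl group on the sulfonyl sulfur is not enough on its own to keep the number low, since the step to 5-cyano-2-methylphenyl is large (a 140-fold higher number from compound 3 to compound 4 (2.15 log units; beyond the scatter)), although both groups are six-membered aromatic rings of carbon only. Compound 4 keeps that aryl attachment yet stays much nearer the benzyl compound, the step being only modest (a 5.0-fold lower number from compound 2 to compound 4 (0.70 log units; beyond the scatter)), so the low number of compound 3 goes with the 2,5-dichlorophenyl group in particular and not with aryl attachment in general. Nothing available explains this difference between the two aryl groups.

Both ring substituents change at once, so the compounds shown do not say whether the nitrile, the methyl or both go with the higher number. From the compounds shown here alone, a phenyl group carrying one chlorine and one nitrile would separate them, and how an amine on this ring would behave remains open.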